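Compound 4: one methoxy fewer than compound 1

A few compounds are considered here, and "the series" means these few. Any claim that something is new, unique, unknown or untested is made for them only; others in the source may bear on it.

Working notes on three measured compounds and one pending. Compound 1 `COc1cc(-c2cc(/C=C/C(=O)c3ccc(N)cc3)[nH]n2)cc(OC)c1OC` gives 102% in a functional assay on TK-10 cells (Homo sapiens) for cytotoxicity, read by sulforhodamine B assay, with a stated time of 48 h, tested at 1 uM; a lower number here means a stronger effect, a higher number a weaker effect of the compound at the concentration tested. Compound 2 `COc1ccc(-c2cc(/C=C/C(=O)c3ccc(OC)c(OC)c3)[nH]n2)cc1` gives 103%, and compound 3 `COc1cc(-c2cc(/C=C/C(=O)c3ccc(Cl)c(Cl)c3)[nH]n2)cc(OC)c1OC` gives 93%. Compound 1 stands second highest of the three numbers; its nearest neighbour is compound 2, within the scatter, and its furthest is compound 3, also within the scatter. Among the compounds with values here, the only single-place step measured is a number 9 percentage points lower from compound 1 to compound 3 (within the scatter), a change of the group on the carbonyl carbon rather than of the shared core, so it does not speak directly to the change now considered. Compound 4 `COc1ccc(-c2cc(/C=C/C(=O)c3ccc(N)cc3)[nH]n2)cc1OC` differs from compound 1 by hydrogen in place of methoxy on an aromatic carbon. Within the data shown here, no measured pair isolates that change; compound 2 carries it together with a second change, and its value and that of compound 1 lie within the scatter of each other. Every comparison available sits within the scatter, so no step beyond it is expected here. Compound 4 is estimated at 100%, range 86% to 112%, which means an expected step of a number 2 percentage points lower from compound 1 to compound 4 (within the scatter).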

Compound 4, a percentage reported as activity, at one concentration (the size of the read-out at that concentration, not a potency): 107%
Beside the measured number, compound 4's estimate is 7 percentage points below it; low and high end bracket the measured number.
By their numbers in this assay, from the lowest: compounds 3, 1, 2 and 4 (each within the scatter of the next, the first and the last beyond it).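

In this assay, hydrogen in place of methoxy on an aromatic carbon, ortho to a methoxy group and meta to a large group, gives a number 5 percentage points higher from compound 1 to compound 4 (within the scatter). This single-place pair isolates a change that compound 2 carried only together with a second one, and it shows that this methoxy can be lost without a step beyond the scatter at the concentration tested. Nothing available gives an explanation for this result.

Open, from the compounds shown here alone, is whether another group in this place, such as a hydroxyl, an amine or a longer alkoxy chain, would give a step beyond the scatter. Also open, going by these compounds, is whether the same change would read alike with 3,4-dichlorophenyl instead of 4-aminophenyl on the carbonyl carbon.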